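The compounds below may be only part of what the source reports. "The series", "measured", "known", "first", "only" and "open" are said of these compounds alone.

For the measured compounds named here, three related compounds have numbers so far in a functional assay on LNCaP cells (Homo sapiens) for cytotoxicity, read by MTT assay, with a stated time of 72 h; on this read-out lower numbers stand for stronger inhibition and higher numbers for weaker inhibition. In this assay compound 1 `CCOc1ccc(/C=C/C(=O)/C=C/C2=C(C)CCCC2(C)C)cc1OCC` gives 8200 nM, compound 2 `CC1=C(/C=C/C(=O)/C=C/c2cc(C(F)(F)F)cc(C(F)(F)F)c2)C(C)(C)CCC1` gives 8700 nM, and compound 3 `CC1=C(/C=C/C(=O)/C=C/c2ccccc2F)C(C)(C)CCC1` gives 10700 nM. The gaps from compound 3 to each of the other two lie within the usual scatter of repeated measurements, so these numbers cannot be told apart, and compound 3 stands level with both.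

Compound 4 `CC1=C(/C=C/C(=O)/C=C/c2ccc(F)cc2)C(C)(C)CCC1` has not yet been measured. It contains the same atoms as compound 3, joined differently: 4-fluorophenyl in place of 2-fluorophenyl on a double-bonded chain carbon bound to a double-bonded chain carbon. Only the 2-fluorophenyl group gives way to the 4-fluorophenyl group, and the rest of the structure stays the same.

Going by the values given here, no two measured compounds differ in just one place, so the data offer no direct measure of a change like this one. The closest guide is indirect: compound 2, at 8700 nM, and compound 3, at 10700 nM, carry different groups at this place, yet their values fall within the scatter. A similar result is therefore expected here, with no shift beyond the scatter in either direction. The expected step is a 1.1-fold lower number from compound 3 to compound 4 (0.05 log units; within the scatter), which is small. For compound 4 the estimated value is 9500 nM, with an expected range of 4700 nM to 19000 nM.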

Compound 4, half-maximal inhibitory concentration: 7300 nM
The estimate for compound 4 lay 1.3-fold (0.11 log units) above the measured number; measured number inside the range.
By their numbers in this assay, from the lowest: compounds 4, 1, 2 and 3 (each within the scatter of the next).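

For the compounds shown here, compound 3 and compound 4 form the first pair here that differs in one place only, so they give the first direct reading of a change at this position: in this assay, 4-fluorophenyl in place of 2-fluorophenyl gives a 1.5-fold lower number from compound 3 to compound 4 (0.17 log units; within the scatter). At this place, on a double-bonded chain carbon bound to a double-bonded chain carbon, this read-out cannot tell the two fluorophenyl groups apart, so for this one pair, where the fluorine sits on the phenyl ring makes no visible difference. No other measurement is available to bear on this result.

This single pair cannot show whether a different kind of group at the same place, such as an amine, a carboxylic acid or a longer chain, would move the number beyond the scatter. It also leaves open how a plain phenyl group with no fluorine would compare with compound 3 and compound 4, and whether changes elsewhere in the shared core would matter more than this one.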